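Cytotoxicity of a pyrimidinyl amide isomer on monkey kidney cells

The source may report more compounds than this note shows. Statements on the series, on what has been measured and on what is new or still open speak of the compounds shown alone.

Compound 3 `CC(C)n1ncc2c(C(=O)Nc3ncccn3)cc(-c3ccsc3)nc21` was tested in an ADME assay on LLC-MK2 cells (Macaca mulatta) for cytotoxicity, read by spectrophotometry and crystal violet staining, with a stated time of 4 days (on this read-out lower numbers stand for higher toxicity in this test and higher numbers for lower toxicity in this test), where compound 3 gives 50000 nM. On the numbers shown it stands level with compound 2 `CC(C)n1ncc2c(C(=O)Nc3ccncn3)cc(-c3cccs3)nc21`, for which this assay gives 50000 nM; together the two are the highest of the three measured values. Compound 1 `CC(C)n1ncc2c(C(=O)Nc3cccnc3)cc(-c3ccsc3)nc21` gives 37000 nM in this assay, and the step of a 1.4-fold higher number from compound 1 to compound 3 (0.13 log units; within the scatter) lies within the scatter.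

Compound 4 `CC(C)n1ncc2c(C(=O)Nc3ccncn3)cc(-c3ccsc3)nc21` differs from compound 3 by pyrimidin-4-yl in place of pyrimidin-2-yl on an amide-type nitrogen. Within the data shown here, no measured step shows exactly this change. Among the measured compounds shown here, the one step that touches this amide-type nitrogen, a 1.4-fold higher number from compound 1 to compound 3 (0.13 log units; within the scatter), was within the scatter. The pyrimidin-4-yl group that enters is already present in compound 2, which differs from compound 4 in another part of the molecule. In this assay compound 2 gives 50000 nM. Compound 4 is therefore expected to show no step beyond the scatter, with no change at the digits printed from compound 3 to compound 4 (within the scatter) as the estimated change. Compound 4 is estimated at 50000 nM, in a range from 25000 nM to 100000 nM.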

Compound 4, half-maximal cytotoxic concentration: > 200000 nM
Compound 4 gave a limit, no number; the forecaster's own chance of this, stated with the estimate: 30%; at least 4.0-fold (0.60 log units) between middle value and limit.
By their numbers in this assay, from the lowest: compounds 1, 2 and 3 (each within the scatter of the next). At a limit, above all of these: compound 4.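

In this assay compound 4 gave a limit and not a number: the limit of > 200000 nM in this assay, at which 1 of the 4 values shown sits. Moving from pyrimidin-2-yl to pyrimidin-4-yl on the amide-type nitrogen, with the same atoms joined differently, gave a step beyond the scatter, an at least 4.0-fold higher number from compound 3 to compound 4 (0.60 log units; beyond the scatter), whereas the earlier change at this nitrogen, a 1.4-fold higher number from compound 1 to compound 3 (0.13 log units; within the scatter), had stayed within it; the step of an at least 5.4-fold higher number from compound 1 to compound 4 (0.73 log units; beyond the scatter) at the same nitrogen is also beyond the scatter. Pyrimidin-4-yl alone does not account for the result, since with that group kept, thiophen-3-yl in place of thiophen-2-yl on an aromatic carbon gave an at least 4.0-fold higher number from compound 2 to compound 4 (0.60 log units; beyond the scatter).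

The compounds shown leave open how pyridin-4-yl, pyrazin-2-yl or a non-aromatic group such as a morpholinoethyl chain on this nitrogen would read. They also leave open whether other rings in place of the thiophene, such as phenyl or furan-3-yl, would keep this result alongside pyrimidin-4-yl.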